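Ether-to-alcohol swap on the piperidine-side chain of compound 3

The compounds below may be only part of what the source reports. "The series", "measured", "known", "first", "only" and "open" are said of these compounds alone.

Notes on the series. Among the measured compounds shown here, in an assay for inhibition of RAC-alpha serine/threonine-protein kinase (Homo sapiens), read by HTRF, with a stated time of 1 h (on this read-out lower numbers stand for stronger inhibition and higher numbers for weaker inhibition), compound 3 `COCC[C@@H]1C[C@@H](c2ccc(Cl)c(Cl)c2)[C@H](NC(=O)c2cc(-c3c(Cl)cnn3C)c(Cl)o2)CN1` gives 7.01 nM, the lowest of the three numbers so far. Compound 2 `Cn1ncc(Cl)c1-c1cc(C(=O)NC2CNCCC2c2ccc(C(F)(F)F)cc2)oc1Cl` gives 7.2 nM, and the two sit within the scatter of each other, so no order between them is claimed. Compound 1 `Cn1ncc(Cl)c1-c1cc(C(=O)N[C@H]2CNCC[C@@H]2c2ccc(C(F)(F)F)cc2)oc1Cl` gives 127 nM, the highest number in the set; the step of an 18-fold lower number from compound 1 to compound 2 (1.25 log units; beyond the scatter) is large and coincides with the fact that one of compounds 1 and 2 is drawn with a defined configuration and the other without, at the place where they differ.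

Compound 4 `Cn1ncc(Cl)c1-c1cc(C(=O)N[C@@H]2CN[C@H](CCCO)C[C@H]2c2ccc(Cl)c(Cl)c2)oc1Cl` differs from compound 3 only at the side chain: hydroxymethyl in place of methoxy on a saturated chain carbon, two bonds along the chain from a saturated ring carbon. For the measured compounds named here, no measured step in this assay concerns an ether-to-alcohol exchange; the only step on record is the stereochemical one between compound 1 and compound 2, which does not bear on this change. Going by the values given here, with no comparable precedent, the expectation for compound 4 is a step of about a 1.1-fold higher number from compound 3 to compound 4 (0.06 log units; within the scatter) in this assay, that is, none beyond the scatter in either direction. Compound 4 is therefore estimated at 8 nM, with a range from 3 nM to 25 nM.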

Compound 4, half-maximal inhibitory concentration: 2.56 nM
Compound 4: middle estimate off by 3.1-fold (0.49 log units), on the high side, and the stated range ends above it.
By their numbers in this assay, from the lowest: compound 4; then compounds 3 and 2 (each within the scatter of the next); then compound 1.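

In this assay, among the compounds shown here, this is the first measured change at the side chain rather than in stereo drawing: 2-methoxyethyl to 3-hydroxypropyl gives a 2.7-fold lower number from compound 3 to compound 4 (0.44 log units; beyond the scatter) and is a modest step beyond the scatter. The position therefore responds to an exchange that leaves the heavy-atom count of the group unchanged, with methoxy at 0 hydrogen-bond donors and hydroxymethyl at 1, and the exchange moves the number down rather than up. For the compounds shown here, nothing on record for these compounds accounts for this step, and the one stereochemical comparison does not bear on it.

The compounds shown leave open whether an amine or a carboxylic acid in place of hydroxymethyl, or a longer chain carrying the hydroxyl, would keep this step. They also leave open whether a shorter chain, such as 2-hydroxyethyl, would do the same.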